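The source may report more compounds than this note shows. Statements on the series, on what has been measured and on what is new or still open speak of the compounds shown alone.

Measured in a functional assay on COLO 205 cells (Homo sapiens) for antiproliferative activity, read by MTT assay, with a stated time of 68 h; a higher number here means a weaker inhibitor, a lower number a stronger inhibitor:
- compound 1 `O=S(=O)(Nc1ccc(F)c(C#Cc2cnc3[nH]ncc3c2)c1F)c1ccccc1`: 2100 nM
- compound 2 `O=S(=O)(Nc1ccc(F)c(C#Cc2cnc3[nH]ncc3c2)c1F)c1ccccn1`: 2670 nM
- compound 3 `O=S(=O)(Nc1ccc(F)c(C#Cc2cnc3[nH]ncc3c2)c1F)c1cccnc1`: 445 nM

Compound 3 has the lowest number of the three, beyond the scatter from both others. Compound 4 `O=S(=O)(Nc1ccc(F)c(C#Cc2ccc3[nH]ncc3c2)c1F)c1cccnc1` keeps the sulfonyl group of compound 3 and differs elsewhere: a group of 9 heavy atoms (7 carbon, 2 nitrogen; one five-membered aromatic ring with 2 hetero atoms, one six-membered aromatic ring of carbon only) in place of a group of 9 heavy atoms (6 carbon, 3 nitrogen; one five-membered aromatic ring with 2 hetero atoms, one six-membered aromatic ring with 1 hetero atom), on a triple-bonded carbon, with 1H-indazol-5-yl now on the triple-bonded carbon. Among the compounds with values here, no measured step touches that place. The available steps all lie on the sulfonyl sulfur: a 1.3-fold higher number from compound 1 to compound 2 (0.10 log units; within the scatter), a 4.7-fold lower number from compound 1 to compound 3 (0.67 log units; beyond the scatter) and a 6.0-fold lower number from compound 2 to compound 3 (0.78 log units; beyond the scatter). They range from nothing beyond the scatter to modest, and give no direction for this change. The expected step is a 1.1-fold higher number from compound 3 to compound 4 (0.05 log units; within the scatter), so no shift beyond the scatter is expected in this assay. Compound 4 is estimated at 500 nM, with an expected range of 130 nM to 2000 nM.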

Compound 4, half-maximal inhibitory concentration: > 10000 nM
Compound 4: only a limit was reported; the forecaster's own chance of this, stated with the estimate: 3%; middle value at least 20-fold (1.30 log units) from the limit.
By their numbers in this assay, from the lowest: compound 3; then compounds 1 and 2 (each within the scatter of the next). At a limit, above all of these: compound 4.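

In this assay, 1H-indazol-5-yl on the triple-bonded carbon gives an at least 22-fold higher number from compound 3 to compound 4 (1.35 log units; beyond the scatter), so this position responds more sharply than the sulfonyl sulfur, where the steps reach only modest size. The two groups differ only in their six-membered aromatic ring, which holds a hetero atom in the group that leaves and carbon only in 1H-indazol-5-yl. The size of this step has no upper bound, since compound 4 is reported only as a limit: the limit of > 10000 nM in this assay, at which 1 of the 4 values shown sits.

From the compounds shown here alone, whether phenyl or pyridin-2-yl on the sulfonyl sulfur would rank the same way with 1H-indazol-5-yl remains open. Also open, going by these compounds, is whether an amine on the six-membered ring of 1H-indazol-5-yl would restore activity.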